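The source may report more compounds than this note shows. Statements on the series, on what has been measured and on what is new or still open speak of the compounds shown alone.

Measured compounds so far:
- Compound 1 `COc1ccc(F)cc1CNCCCNc1ccnc2cc(C3CCCCC3)ccc12` gives 2290 nM in an ADME assay on HepG2 cells (Homo sapiens) for cytotoxicity, read by luminescence, CellTiter-Glo and ATP content, with a stated time of 72 h; on this read-out lower numbers stand for an effect already at smaller amounts and higher numbers for an effect only at larger amounts of compound.
- Compound 2 `COc1ccc(F)cc1CNCCCNc1ccnc2cc(CCC(C)C)ccc12` gives 890 nM in this assay.
- Compound 3 `CCC(CC)c1ccc2c(NCCCNCc3cc(F)ccc3OC)ccnc2c1` gives 7860 nM in this assay.

Compound 3 stands highest of the three numbers in this assay; the gap to its nearest neighbour is a 3.4-fold higher number from compound 1 to compound 3 (0.54 log units; beyond the scatter), and to the furthest an 8.8-fold higher number from compound 2 to compound 3 (0.95 log units; beyond the scatter).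

Compound 4 `COc1ccc(F)cc1CNCCCNc1ccnc2cc(Cc3cccc(C(F)(F)F)c3)ccc12` is the next compound to be measured. It differs from compound 3 in one place: 3-(trifluoromethyl)benzyl in place of pentan-3-yl on an aromatic carbon.

All three measured steps change the group on this same aromatic carbon, and all are modest: a 2.6-fold lower number from compound 1 to compound 2 (0.41 log units; beyond the scatter), a 3.4-fold higher number from compound 1 to compound 3 (0.54 log units; beyond the scatter), an 8.8-fold higher number from compound 2 to compound 3 (0.95 log units; beyond the scatter). Within the data shown here, every one of them swaps one saturated group for another; none puts a six-membered aromatic ring of carbon only at this position, and none carries a trifluoromethyl group, so there is no direct precedent for the change to compound 4. The spread seen so far across this position is modest in both directions, and since compound 3 holds the highest number, the expectation for compound 4 is a modest step toward a lower number in this assay, placing it in the region of compound 1 and compound 2.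

The estimated step is a 3.1-fold lower number from compound 3 to compound 4 (0.50 log units; beyond the scatter). Compound 4 is therefore expected to give about 2500 nM in this assay, within a range of 700 nM to 9000 nM.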

Compound 4, half-maximal effective concentration: 440 nM
Estimate against measurement, compound 4: 5.7-fold (0.75 log units) above, and the stated range ends above it.
By their numbers in this assay, from the lowest: compound 4; then compound 2; then compound 1; then compound 3.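

In this assay, among these compounds, 3-(trifluoromethyl)benzyl, the first group at this aromatic carbon with a six-membered aromatic ring of carbon only and a trifluoromethyl group, gives the largest step seen at this position (an 18-fold lower number from compound 3 to compound 4 (1.25 log units; beyond the scatter)) and also lies beyond the scatter against the other two groups (a 2.0-fold lower number from compound 2 to compound 4 (0.31 log units; beyond the scatter); a 5.2-fold lower number from compound 1 to compound 4 (0.72 log units; beyond the scatter)), so the lowest number of the series no longer belongs to a saturated group. Isopentyl and 3-(trifluoromethyl)benzyl, both with an unbranched carbon on the aromatic carbon, now hold the two lowest numbers, while cyclohexyl and pentan-3-yl, both branched at that carbon, hold the two highest, and none of the four compounds goes against this. No measurement at hand accounts for the size of these differences.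

The compounds shown cannot separate the contribution of the aromatic ring from that of the trifluoromethyl group, since plain benzyl is not among them. They also leave open how this position responds to a group carrying an amine or a carboxylic acid, and whether a longer chain between the ring and the core keeps the low number.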